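A few compounds are considered here, and "the series" means these few. Any claim that something is new, unique, unknown or untested is made for them only; others in the source may bear on it.

In a functional assay on the whole organism (strain Sprague-Dawley) for inhibition, with Rattus norvegicus as the target (a lower number here means that less compound is needed, a higher number that more compound is needed for the effect), compound 1 `COc1cccc2cc(C(=O)O)cnc12` gives 150 mg/kg, the higher of the two numbers shown, though its gap to compound 2 lies within the scatter. Compound 2 `O=C(O)c1cnc2c(C(F)(F)F)cccc2c1` gives 75 mg/kg, and in this assay there is a 2.0-fold lower number from compound 1 to compound 2 (0.30 log units; within the scatter). Compound 3 `Cc1cccc2cc(C(=O)O)cnc12` gives only a limit, > 25 mg/kg. That leaves a step that the limit leaves unreadable from compound 1 to compound 3 and likewise a step that the limit leaves unreadable from compound 2 to compound 3. Compound 4 `COc1ccc(OC)c2ncc(C(=O)O)cc12` differs from compound 1 by methoxy in place of hydrogen on an aromatic carbon. Within the data shown here, every measured step swaps one group for another at a single place; none adds a methoxy, so no measured step bears on this change, and the expected step for compound 4 is no change at the digits printed from compound 1 to compound 4 (within the scatter), with no direction beyond the scatter. Compound 4 is therefore estimated at about 150 mg/kg, between 50 mg/kg and 400 mg/kg in this assay.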

Compound 4, minimum effective dose: > 50 mg/kg
Compound 4: no number, only a limit; the forecaster's own chance of this, stated with the estimate: 30%; the middle value is on the limit's open side.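

Compound 4 gives only a limit, > 50 mg/kg, not a number, so the step to it from compound 1 cannot be read. The compounds shown leave open whether the added methoxy changes the dose needed at all.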